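A Smaller Group on the Five-Membered Ring of Compound 2

A few compounds are considered here, and "the series" means these few. Any claim that something is new, unique, unknown or untested is made for them only; others in the source may bear on it.

Among the measured compounds shown here, compound 2 `O=C(O)c1ccccc1-c1ccc(CCc2ncc(CC3CCCCCC3)[nH]2)cc1` gives 88 nM in an in vitro functional assay on cells for agonist activity at Bombesin receptor subtype-3 (Homo sapiens), read by luminescence and calcium flux (on this read-out lower numbers stand for an effect already at smaller amounts and higher numbers for an effect only at larger amounts of compound), the lowest of the three numbers known. Compound 3 `N#Cc1cccc(Cc2cnc(CCc3ccc(-c4ccccc4C(=O)O)cc3)[nH]2)c1` gives 812 nM, and compound 1 `CCCCc1cnc(C(CC)Cc2ccc(-c3ccccc3C(=O)O)cc2)[nH]1` gives 2720 nM. Compound 4 `CC(C)(C)c1cnc(CCc2ccc(-c3ccccc3C(=O)O)cc2)[nH]1` differs from compound 2 in one place: tert-butyl in place of cycloheptylmethyl on an aromatic carbon. For the measured compounds named here, the only single-place step known, a 9.2-fold higher number from compound 2 to compound 3 (0.97 log units; beyond the scatter), shows the number rising when the cycloheptyl is replaced by 3-cyanophenyl; compound 1, which carries a straight butyl chain rather than a cycloheptyl, stands far higher than compound 2 as well. Both point to a weaker result once the cycloheptyl ring is gone, so compound 4 is expected to show a rise of a 6.8-fold higher number from compound 2 to compound 4 (0.83 log units; beyond the scatter). Compound 4 is therefore estimated at 600 nM, within a range from 150 nM to 2500 nM.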

Compound 4, half-maximal effective concentration: 4330 nM
For compound 4 the middle estimate is 7.2-fold (0.86 log units) below the measured one; measured number above the stated range.
By their numbers in this assay, from the lowest: compound 2; then compound 3; then compounds 1 and 4 (each within the scatter of the next).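

At the aromatic carbon of the five-membered ring in this assay, tert-butyl in place of cycloheptylmethyl gives a 49-fold higher number from compound 2 to compound 4 (1.69 log units; beyond the scatter) and so removes most of the effect seen with compound 2. Compound 3 also stands lower than the ring-free compound 4, with tert-butyl in place of 3-cyanobenzyl giving a 5.3-fold higher number from compound 3 to compound 4 (0.73 log units; beyond the scatter) as its step. Among these three compounds, then, both groups that carry a ring give lower numbers than tert-butyl. From the compounds shown here alone, whether the ring itself or simply the larger group counts stays open, since a straight octyl chain or a cyclopentylmethyl group could separate the two. Nothing further is at hand that would explain these steps.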